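This account rests on a few compounds, and the source may have more. Where it says the series, first, only, none or still open, it means among the compounds named here.

The set comprises three measured compounds and one still to be tested, all built on a shared amide scaffold. Compound 1 `O=C(CCc1cn(Cc2ccccc2)c2ccc(F)cc12)Nc1ccncc1` and compound 2 `O=C(CCc1cn(Cc2ccc(F)cc2)c2ccc(F)cc12)Nc1ccncc1` differ only in fluoro in place of hydrogen on an aromatic carbon. In a functional assay for inhibition, with Rattus norvegicus as the target (on this read-out lower numbers stand for stronger inhibition and higher numbers for weaker inhibition), compound 1 gives 420 nM, and in this assay compound 2 gives 380 nM, so that the step of a 1.1-fold lower number from compound 1 to compound 2 (0.04 log units; within the scatter). Compound 3 `CC(C)c1ccc2c(c1)c(CCC(=O)Nc1ccncc1)cn2Cc1ccccc1` has a different core, the difference between the two cores being (isopropyl in place of fluoro on an aromatic carbon). In this assay compound 3 gives 6000 nM, the highest number of the three, the step being a 14-fold higher number from compound 1 to compound 3 (1.15 log units; beyond the scatter).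

Compound 4 `CC(C)c1ccc2c(c1)c(CCC(=O)Nc1ccncc1)cn2Cc1ccc(F)cc1` has not been measured. It stands to compound 3 exactly as compound 2 stands to compound 1: the change is fluoro in place of hydrogen on an aromatic carbon, and since the place of the change reads the same in both pairs, it is the same change, made on the core of compound 3 rather than on that of compound 1. Among the measured compounds shown here, the only guide to its effect is the earlier pair. Because a 1.1-fold lower number from compound 1 to compound 2 (0.04 log units; within the scatter) lies within the scatter, the same change on compound 3 is expected to move the number little, which would mean a 1.1-fold lower number from compound 3 to compound 4 (0.04 log units; within the scatter). Whether the change behaves alike on a core that carries isopropyl in place of fluoro is not shown by any other pair, so the expectation is loose. Compound 4 is therefore estimated at 5500 nM in this assay. The expected range for compound 4 runs from 2500 nM to 12000 nM.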

Compound 4, half-maximal inhibitory concentration: 5340 nM
For compound 4 the middle estimate is 1.0-fold (0.01 log units) above the measured one; low and high end bracket the measured number.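

In this assay, the change from benzyl to 4-fluorobenzyl on the core of compound 3 gives a 1.1-fold lower number from compound 3 to compound 4 (0.05 log units; within the scatter), and it reads the same as on the core of compound 1: the same change on two cores in this assay, a 1.1-fold lower number (0.04 log units; within the scatter) from compound 1 to compound 2 and a 1.1-fold lower number (0.05 log units; within the scatter) from compound 3 to compound 4, 1.0-fold (0.01 log units) apart, within the scatter of two such steps The other change, isopropyl in place of fluoro, read on the two compounds that carry 4-fluorobenzyl, gives a 14-fold higher number from compound 2 to compound 4 (1.15 log units; beyond the scatter), and this large step also matches its earlier counterpart: the same change on two cores in this assay, a 14-fold higher number (1.15 log units; beyond the scatter) from compound 1 to compound 3 and a 14-fold higher number (1.15 log units; beyond the scatter) from compound 2 to compound 4, 1.0-fold (0.01 log units) apart, within the scatter of two such steps Across these four compounds, then, each change carries from one core to the other with its size intact, the fluoro change staying within the scatter and the isopropyl change staying large, but this rests on a single square of compounds in one whole-organism read-out and shows neither why the steps match nor that they would match on any further core.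

The compounds shown leave open whether chloro or methoxy in place of the fluoro of 4-fluorobenzyl would also leave the number where it stands, and whether methyl or ethyl in place of isopropyl would give a step of lesser size. They also leave open how a longer chain between the core and the carbonyl would behave on either core.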